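The source may hold more compounds than are shown below. What is called first, only, known or untested is meant among the compounds shown, and "the series" means these compounds.

Compound 1 `c1ccc(-c2cn3ccnc3c(-c3ccc4ncn(C5CCCCC5)c4c3)n2)cc1` gives 9.15% in a functional assay on SW-620 cells (Homo sapiens) for inhibition, read by sulforhodamine B assay, with a stated time of 48 h, tested at 10 uM; a higher number here means more inhibition at the concentration tested (going by the name of the read-out), a lower number less inhibition. Compound 2 `O=Cc1ccc(-c2cn3ccnc3c(-c3ccc4ncn(C5CCCCC5)c4c3)n2)cc1` gives 4.21% in this assay.

Among the two measured compounds, compound 1 has the higher number in this assay, but the only measured step, a number 4.9 percentage points lower from compound 1 to compound 2 (within the scatter), is within the scatter, so the two numbers count as level; for both compounds the inhibition in this assay at the tested concentration is a low number.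

Compound 3 `COc1ccccc1-c1cn2ccnc2c(-c2ccc3ncn(C4CCCCC4)c3c2)n1` differs from compound 1 by the change (methoxy in place of hydrogen on an aromatic carbon). Going by the values given here, no measured step covers this exact change. Among the compounds with values here, the one step that is known, formyl in place of hydrogen on an aromatic carbon, in a number 4.9 percentage points lower from compound 1 to compound 2 (within the scatter), shows that adding a small group to this phenyl ring did not move the number beyond the scatter. On that basis the step of a number 1.2 percentage points lower from compound 1 to compound 3 (within the scatter) is expected to be small, with no clear direction beyond the scatter. Compound 3 is therefore estimated at 8%, in the range -2% to 20%.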

Compound 3, a percentage reported as inhibition, at one concentration (the size of the read-out at that concentration, not a potency): 3.4%
For compound 3 the middle estimate is 4.6 percentage points above the measured one; the range from low to high includes it.
By their numbers in this assay, from the lowest: compounds 3, 2 and 1 (each within the scatter of the next).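

Methoxy ortho to a large group gives a number 5.8 percentage points lower from compound 1 to compound 3 (within the scatter), so a second kind of added group, at a second place on the phenyl ring, also leaves the number in this assay level with the unsubstituted compound. Exchanging one substituted ring for the other, 2-methoxyphenyl in place of 4-formylphenyl, gives a number 0.8 percentage points lower from compound 2 to compound 3 (within the scatter), so all three compounds now count as level, and all three numbers are low. Nothing available explains why these changes leave the number level.

As far as these compounds go, it remains open whether an amine or a carboxylic acid on this phenyl ring would move the number beyond the scatter. Also open, from the compounds shown here alone, is whether methoxy at another place on the ring would read any differently from this one.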